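Replacing 4-methylpiperazin-1-yl with 1H-imidazol-1-yl on Compound 3

A few compounds are considered here, and "the series" means these few. Any claim that something is new, unique, unknown or untested is made for them only; others in the source may bear on it.

Three measured compounds share one core and differ in the group on a ring nitrogen. In a functional assay on HCC1806 cells (Homo sapiens) for inhibition, read by sulforhodamine B assay, tested at 10 uM (a higher number here means more inhibition at the concentration tested (going by the name of the read-out), a lower number less inhibition), compound 1 `COC(=O)CC(=O)N1N=C(c2ccc(N3CCN(C)CC3)cc2)CC1c1ccc(N(C)C)cc1` gives -8.3%, compound 2 `CN1CCN(c2ccc(C3=NN(C(=O)/C=C/c4ccccc4)C(c4ccc(N(C)C)cc4)C3)cc2)CC1` gives 71%, and compound 3 `CN1CCN(c2ccc(C3=NN(S(C)(=O)=O)C(c4ccc(N(C)C)cc4)C3)cc2)CC1` gives -18.5%, the lowest of the three. The steps to compound 3 were a number 10.2 percentage points lower from compound 1 to compound 3 (beyond the scatter) and a number 89.5 percentage points lower from compound 2 to compound 3 (beyond the scatter). Compound 4 `CN(C)c1ccc(C2CC(c3ccc(-n4ccnc4)cc3)=NN2S(C)(=O)=O)cc1` keeps the methylsulfonyl group of compound 3 and alters a different part: 1H-imidazol-1-yl in place of 4-methylpiperazin-1-yl on an aromatic carbon. Among the measured compounds shown here, none of the measured steps touches this position, so none bears directly on the change. Lacking such guidance, the step of a number 8.5 percentage points higher from compound 3 to compound 4 (within the scatter) is expected to lie within the scatter. Compound 4 is therefore estimated at -10%, with a range from -32% to 14%.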

Compound 4, a percentage reported as inhibition, at one concentration (the size of the read-out at that concentration, not a potency): 11.3%
Compound 4: middle estimate off by 21.3 percentage points, on the low side, and the stated range covers the measured number.
By their numbers in this assay, from the lowest: compound 3; then compound 1; then compound 4; then compound 2.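

With the methylsulfonyl group held fixed, replacing 4-methylpiperazin-1-yl with 1H-imidazol-1-yl gives a number 29.8 percentage points higher from compound 3 to compound 4 (beyond the scatter) in this assay and so shows that this position also moves the read-out. The earlier steps shown here changed only the group on the ring nitrogen. Nothing available explains this step. The compounds shown leave open whether the same swap would also raise the number with the (2-phenylethenyl)carbonyl group of compound 2 on the ring nitrogen. They also leave open how a morpholine or a pyridine ring would fare at this position.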